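A few compounds are considered here, and "the series" means these few. Any claim that something is new, unique, unknown or untested is made for them only; others in the source may bear on it.

Measured so far in a functional assay on the whole organism with Rattus norvegicus as the target, at a dose of 20 mg/kg by the oral route; a lower number here means less inhibition, a higher number more inhibition at the dose given (going by the name of the read-out):

Compound 1, `CNC(=O)/C=C1\CCc2ccc(Br)cc21`: 53%
Compound 2, `CNC(=O)/C=C1\CCc2ccc(Cl)cc21`: 25%
Compound 3, `CNC(=O)/C=C1\CCc2ccc(F)cc21`: 38%

Compound 1 stands highest of the three, with compound 3 nearest (a number 15 percentage points lower from compound 1 to compound 3 (beyond the scatter)) and compound 2 furthest (a number 28 percentage points lower from compound 1 to compound 2 (beyond the scatter)). Between the two smaller halogens the step runs a number 13 percentage points higher from compound 2 to compound 3 (beyond the scatter). All three measured steps concern the halogen on the aromatic carbon; none touches the amide end of the shared core.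

Compound 4, `NC(=O)/C=C1\CCc2ccc(Br)cc21`, differs from compound 1 by hydrogen in place of methyl on an amide-type nitrogen. Among the compounds with values here, no measured pair in this set changes anything on the amide-type nitrogen, so the halogen steps give no direct guidance on the size or direction of this change. The expectation therefore rests on the value of compound 1 alone, 53%, with a wide band around it. For compound 4 the estimate is 45% (range 15% to 72%), i.e. an expected step of a number 8 percentage points lower from compound 1 to compound 4 (within the scatter), not clearly beyond the scatter in either direction.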

Compound 4, a percentage reported as inhibition, in the whole organism at one dose (the size of the read-out at that dose, not a potency): 21%
Compound 4: middle estimate off by 24 percentage points, on the high side; measured number inside the range.
By their numbers in this assay, from the lowest: compounds 4 and 2 (each within the scatter of the next); then compound 3; then compound 1.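

In this assay, the amide end of the shared core proves not to be a silent position: with bromo held fixed on the aromatic carbon, hydrogen in place of methyl on the amide-type nitrogen gives a number 32 percentage points lower from compound 1 to compound 4 (beyond the scatter). The read-out at this dose therefore responds to the substituent on this nitrogen as well as to the halogen, and in this one pair the methylcarbamoyl compound stands above the carbamoyl compound. Nothing at hand bears on why the step occurs.

From the compounds shown here alone, whether the same change has a similar effect with chloro or fluoro on the aromatic carbon remains open, since the step rests on the bromo pair alone. Also open, going by these compounds, is what an ethyl group, a longer chain or a second methyl on the amide-type nitrogen would give.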